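Swapping a Methoxy Ring for an Acetamido-Chloro Ring

The source may hold more compounds than are shown below. What is called first, only, known or untested is meant among the compounds shown, and "the series" means these compounds.

Three measured compounds share one core and differ only in the group carried on a single nitrogen at its edge. Compound 1 `Cc1ccc(S(=O)(=O)Nc2cccc(-c3nc(-c4ccc(NC(=O)c5cccnc5)cc4Cl)no3)c2)cc1` bears a (4-methylphenyl)sulfonyl group there. In a functional assay on MDA-MB-231 cells (Homo sapiens) for antiproliferative activity, read by MTT assay, with a stated time of 72 h (a higher number here means a weaker inhibitor, a lower number a stronger inhibitor), compound 1 gives only a limit, > 10000 nM (the limit of > 10000 nM in this assay, at which 1 of the 3 values shown sits). Compound 2 `COc1ccc(NC(=O)Nc2cccc(-c3nc(-c4ccc(NC(=O)c5cccnc5)cc4Cl)no3)c2)cc1` carries a (4-methoxyphenyl)carbamoyl group in its place; in this assay compound 2 gives 3000 nM, the highest of the two plain numbers. Compound 3 `O=C(Nc1ccc(NS(=O)(=O)C2CC2)cc1)Nc1cccc(-c2nc(-c3ccc(NC(=O)c4cccnc4)cc3Cl)no2)c1` has (cyclopropylsulfonyl)amino where compound 2 has methoxy, and in this assay compound 3 gives 300 nM. The two measured steps, an at least 3.3-fold lower number from compound 1 to compound 2 (0.52 log units; beyond the scatter) and a 10-fold lower number from compound 2 to compound 3 (1.00 log units; beyond the scatter), both lowered the number.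

Compound 4 `CC(=O)Nc1ccc(NC(=O)Nc2cccc(-c3nc(-c4ccc(NC(=O)c5cccnc5)cc4Cl)no3)c2)cc1Cl` has not yet been measured. Its difference from compound 2 is 4-acetamido-3-chlorophenyl in place of 4-methoxyphenyl on an amide-type nitrogen. The step from compound 2 to compound 3 is the one that bears on it: there, too, the methoxy-bearing ring gave way to a ring carrying a group with one hydrogen-bond donor and one acceptor, and the number fell by a modest amount. A lower number is therefore expected for compound 4, with the step estimated at a 5.0-fold lower number from compound 2 to compound 4 (0.70 log units; beyond the scatter). The estimate for compound 4 is 600 nM, with a range from 200 nM to 2000 nM.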

Compound 4, half-maximal inhibitory concentration: > 10000 nM
Compound 4: a limit, no number (the forecaster's own chance of this, stated with the estimate: 5%); middle value at least 16-fold (1.22 log units) from the limit.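

This step runs against the earlier ones: both of those lowered the number, whereas on this amide-type nitrogen, 4-acetamido-3-chlorophenyl in place of 4-methoxyphenyl gives an at least 3.3-fold higher number from compound 2 to compound 4 (0.52 log units; beyond the scatter). A ring group with a hydrogen-bond donor and a hydrogen-bond acceptor therefore does not by itself bring the improvement seen in a 10-fold lower number from compound 2 to compound 3 (1.00 log units; beyond the scatter), so the outcome at this position depends on more than those counts. In this assay compound 4 gives > 10000 nM, which is a limit and not a number, so the full size of the loss cannot be read, and compound 4 now sits with compound 1 at the same limit: the limit of > 10000 nM in this assay, at which 2 of the 4 values shown sit.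

The acetamido group and the chlorine enter together in compound 4, so the compounds shown cannot assign the step to either one, and a 4-acetamidophenyl ring without chlorine or a 3-chloro-4-methoxyphenyl ring would separate the two. Also open, from the compounds shown here alone, is how a plain amine or a carboxylic acid at the 4-position of this ring would read in this assay.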